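The source may report more compounds than this note shows. Statements on the series, on what has been measured and on what is new or still open speak of the compounds shown alone.

Measured compounds:
- Compound 1, `O=C(O)c1ccccc1-c1ccc(CCc2ncc(C3CCCCC3)[nH]2)cc1`: 14.7 nM
- Compound 2, `Cc1ccccc1Cc1cnc(CCc2ccc(-c3ccccc3C(=O)O)cc2)[nH]1`: 9.3 nM
- Compound 3, `Cc1cccc(Cc2cnc(CCc3ccc(-c4ccccc4C(=O)O)cc3)[nH]2)c1`: 75 nM

These three share one core and differ only in the group attached to it, and all were tested in an in vitro functional assay on cells for agonist activity at Bombesin receptor subtype-3 (Mus musculus), read by luminescence and calcium flux; a higher number here means that more compound is needed for the effect, a lower number that less compound is needed. Compound 2 gives the lowest of the three numbers: compound 1 sits nearest, with a 1.6-fold lower number from compound 1 to compound 2 (0.20 log units; within the scatter), a gap that lies within the scatter, while compound 3 sits furthest, with an 8.1-fold higher number from compound 2 to compound 3 (0.91 log units; beyond the scatter).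

Compound 4, `CCC(C)(CC)Cc1cnc(CCc2ccc(-c3ccccc3C(=O)O)cc2)[nH]1`, has not yet been measured. It differs from compound 2 in one place: 1-ethyl-1-methylpropyl in place of 2-methylphenyl on a saturated chain carbon bound to an aromatic carbon. Among the measured compounds shown here, two measured steps bear on this change. The step from a saturated ring to the aromatic group, a 1.6-fold lower number from compound 1 to compound 2 (0.20 log units; within the scatter), was small, so swapping between saturated and aromatic groups at this place did not move the number much. The step of an 8.1-fold higher number from compound 2 to compound 3 (0.91 log units; beyond the scatter) shows, however, that the exact shape of the group here can matter. For the measured compounds named here, no measured compound carries a branched chain, so the direction is uncertain; a modest rise from compound 2, or none beyond the scatter, seems the most likely outcome, and compound 4 is expected to show a 2.2-fold higher number from compound 2 to compound 4 (0.33 log units; beyond the scatter).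

Compound 4 is therefore estimated to give 20 nM, with a range from 6 nM to 70 nM.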

Compound 4, half-maximal effective concentration: 30 nM
For compound 4 the middle estimate is 1.5-fold (0.18 log units) below the measured one; the range from low to high includes it.
By their numbers in this assay, from the lowest: compounds 2 and 1 (each within the scatter of the next); then compound 4; then compound 3.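

Among the compounds shown here, compound 4 is the only compound here whose group on the saturated chain carbon bound to an aromatic carbon has no ring, and in this assay its number falls between those of the two methylphenyl compounds (a 3.2-fold higher number from compound 2 to compound 4 (0.51 log units; beyond the scatter) and a 2.5-fold lower number from compound 3 to compound 4 (0.40 log units; beyond the scatter)). A ring in this group is therefore not needed to reach this range, since the open, branched 1-ethyl-1-methylpropyl group gives a lower number than the 3-methylphenyl group of compound 3, though not as low as the 2-methylphenyl group of compound 2. The comparison with the cyclohexyl compound points the same way, with only a modest change (a 2.0-fold higher number from compound 1 to compound 4 (0.31 log units; beyond the scatter)), and no measurement shown here explains why these groups rank in this order.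

As far as these compounds go, with a single branched chain in the set, it remains open whether a tert-butyl group or a straight hexyl chain would give a number like that of compound 4. From the compounds shown here alone, it is equally open how the number would respond to an amine or an ether oxygen placed in this group.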